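A few compounds are considered here, and "the series" means these few. Any claim that something is new, unique, unknown or untested is made for them only; others in the source may bear on it.

Of the compounds shown here, three with the same core have been measured in an ADME assay on the whole organism (Rattus norvegicus), at a dose of 2 mg/kg by the oral route; a higher number here means more compound in the circulation at the dose given, a lower number less compound in the circulation: compound 1 `COc1cc(OCc2csc(-c3ccc(C(C)(C)O)cc3)n2)c2cc(-c3cn4nc(OC)sc4n3)oc2c1` gives 505 ng.h/mL, compound 2 `CNC(=O)c1ccc(-c2nc(COc3cc(OC)cc4oc(-c5cn6nc(OC)sc6n5)cc34)cs2)cc1` gives 21.9 ng.h/mL, and compound 3 `COc1cc(OCc2csc(-c3ccc(S(C)(=O)=O)cc3)n2)c2cc(-c3cn4nc(OC)sc4n3)oc2c1` gives 148 ng.h/mL. Compound 3 therefore stands second of the three, under compound 1 and over compound 2. The next structure, compound 4 `COc1cc(OCc2csc(-c3ccccc3)n2)c2cc(-c3cn4nc(OC)sc4n3)oc2c1`, differs from it in one place: hydrogen in place of methylsulfonyl on an aromatic carbon. This is hydrogen in place of methylsulfonyl on an aromatic carbon, so 4-(methylsulfonyl)phenyl becomes phenyl.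

Three measured steps exchange groups at this same place: a 3.4-fold lower number from compound 1 to compound 3 (0.53 log units; beyond the scatter), a 6.8-fold higher number from compound 2 to compound 3 (0.83 log units; beyond the scatter) and a 23-fold lower number from compound 1 to compound 2 (1.36 log units; beyond the scatter). All lie beyond the scatter, so the group here clearly matters, but each step swaps one group for another. Among the measured compounds shown here, no measured compound has hydrogen at this place, so these steps suggest how wide the range should be, not which direction to expect. On these data alone, no clear step is therefore expected in this assay, and either direction remains open. The expected step is a 1.2-fold higher number from compound 3 to compound 4 (0.09 log units; within the scatter). The estimate for compound 4 is 180 ng.h/mL, with an expected range from 45 ng.h/mL to 700 ng.h/mL.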

Compound 4, area under the concentration-time curve: 3920 ng.h/mL
Beside the measured number, compound 4's estimate is 22-fold (1.34 log units) below it; the whole stated range lies below it.
By their numbers in this assay, from the lowest: compound 2; then compound 3; then compound 1; then compound 4.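

In this assay the plain phenyl of compound 4 stands above all three substituted compounds, with a 26-fold higher number from compound 3 to compound 4 (1.42 log units; beyond the scatter) and a 180-fold higher number from compound 2 to compound 4 (2.25 log units; beyond the scatter) and also a 7.8-fold higher number from compound 1 to compound 4 (0.89 log units; beyond the scatter) in the same direction. The earlier compounds shown here only ranked methylsulfonyl, methylcarbamoyl and 1-hydroxy-1-methylethyl against one another; hydrogen now gives them a common reference and shows that each of the three, on this aromatic carbon para to a large group, goes with a lower number than no group at all. Nothing given here accounts for the size of these steps. Still open, on these data alone, is whether a single fluorine or a methyl at this place would keep the number near that of compound 4, or whether any larger group lowers it. An amine or a carboxylic acid here would test the same question.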